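The source may hold more compounds than are shown below. What is called first, only, known or untested is meant among the compounds shown, and "the series" means these compounds.

Within the data shown here, in an assay on cells with melanin-concentrating hormone receptor 1 (Homo sapiens) as the target, read by radioligand binding (on this read-out lower numbers stand for stronger inhibition and higher numbers for weaker inhibition), compound 2 `Nc1ccc2cccc(OCC3CCCC3)c2n1` gives 53 nM, the lowest number among the three compounds measured so far. Compound 3 `Nc1ccc2cccc(OC3CCCCCC3)c2n1` gives 137 nM, a higher number that lies beyond the scatter, and compound 1 `CC1CCCC(Oc2cccc3ccc(N)nc23)C1` gives 640 nM, the highest of the three and also beyond the scatter from compound 2. Compound 4 `CCCOc1cccc2ccc(N)nc12` has not yet been measured in this assay. Its difference from compound 2 is ethyl in place of cyclopentyl on a saturated chain carbon bound to an oxygen on an aromatic ring. Among the measured compounds shown here, no pair of measured compounds shows this exact change, so the expectation rests on the spread of the three numbers alone. A step toward a weaker number, beyond the scatter, is expected, estimated at a 4.7-fold higher number from compound 2 to compound 4 (0.67 log units; beyond the scatter). The estimate for compound 4 is 250 nM, with a range from 80 nM to 800 nM.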

Compound 4, half-maximal inhibitory concentration: 1100 nM
For compound 4 the middle estimate is 4.4-fold (0.64 log units) below the measured one; the measured number lies above the stated range.
By their numbers in this assay, from the lowest: compound 2; then compound 3; then compounds 1 and 4 (each within the scatter of the next).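

In this assay, among these compounds, ethyl in place of cyclopentyl on a saturated chain carbon bound to an oxygen on an aromatic ring gives a 21-fold higher number from compound 2 to compound 4 (1.32 log units; beyond the scatter), the first step between measured compounds that differ in one place. It shows that this position is sensitive to the group it carries, as this single change gives a large step toward weaker inhibition. Nothing available explains this step. The compounds shown leave open whether the ring itself or simply the larger carbon group matters, which a longer open chain such as pentyl could help to separate. On these data alone, how an amine on the cyclopentyl ring would fare also remains open.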